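Hydroxy to methoxy: one step measured, one expected

The source may report more compounds than this note shows. Statements on the series, on what has been measured and on what is new or still open speak of the compounds shown alone.

Working notes on a small set with one shared change. Compound 1 `O=C(Nc1cccc(-n2cc(-c3ccncc3)c(-c3cc(O)cc(Cl)c3)n2)c1)Nc1ccc(Cl)c(C(F)(F)F)c1` carries a free hydroxy on its chlorophenyl ring; in a functional assay on A498 cells (Homo sapiens) for inhibition, read by sulforhodamine B assay, with a stated time of 48 h, tested at 10 uM (on this read-out lower numbers stand for a stronger effect and higher numbers for a weaker effect at the one concentration tested), compound 1 gives 21.5%. Compound 2 `COc1cc(Cl)cc(-c2nn(-c3cccc(NC(=O)Nc4ccc(Cl)c(C(F)(F)F)c4)c3)cc2-c2ccncc2)c1` differs from compound 1 only by methyl in place of hydrogen on an oxygen on an aromatic ring, and in this assay compound 2 gives -9.18%. The step is a number 30.7 percentage points lower from compound 1 to compound 2 (beyond the scatter), so the methyl on the oxygen pushes the read-out toward a stronger effect in this pair.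

Compound 3 `O=C(Nc1cccc(-n2cc(-c3ccncc3)c(-c3cc(O)cc(Cl)c3)n2)c1)c1cc(C(F)(F)F)cc(C(F)(F)F)c1` carries the same chlorophenyl with hydroxy, but its core is not that of compound 1; the difference between the two cores is not broken down here. In this assay compound 3 gives 40.3%, the highest number of the three, beyond the scatter against both compound 1 and compound 2.

Compound 4 `COc1cc(Cl)cc(-c2nn(-c3cccc(NC(=O)c4cc(C(F)(F)F)cc(C(F)(F)F)c4)c3)cc2-c2ccncc2)c1` is the counterpart of compound 3 that carries methyl in place of hydrogen on an oxygen on an aromatic ring. The place is the same as in the pair of compound 1 and compound 2, so this is the same change on a different core. Among the compounds with values here, the one precedent is the step from compound 1 to compound 2, measured at a number 30.7 percentage points lower from compound 1 to compound 2 (beyond the scatter); with a single example on another core, the expectation for compound 4 is a step of similar direction and roughly similar size, a number 28.3 percentage points lower from compound 3 to compound 4 (beyond the scatter), with a wide band. Compound 4 is therefore expected to give about 12% in this assay, estimated to lie between -12% and 36%.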

Compound 4, a percentage reported as activity, at one concentration (the size of the read-out at that concentration, not a potency): -1.74%
For compound 4 the middle estimate is 13.7 percentage points above the measured one, and the stated range covers the measured number.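

In this assay the change from hydroxy to methoxy gives a number 42 percentage points lower from compound 3 to compound 4 (beyond the scatter) on the core of compound 3, which is the same direction as on the core of compound 1, so in this series the change carries over between these two cores. The two steps also agree in size within what repeated measurements can separate, so neither core can be said to respond more strongly to the change: the same change on two cores in this assay, a number 30.7 percentage points lower (beyond the scatter) from compound 1 to compound 2 and a number 42 percentage points lower (beyond the scatter) from compound 3 to compound 4, 11.4 percentage points apart, within the scatter of two such steps. Within the data shown here, this rests on only two pairs and on a single read-out at one concentration, so it does not show that the step would hold on a third core, gives no potency for any compound, and says nothing about why the methyl on the oxygen has this effect.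

Still open, as far as these compounds go, is whether the effect belongs to methoxy alone or extends to a longer chain on the same oxygen, such as ethoxy, or to a different group at that place, such as an amine or a fluorine in place of the hydroxy. Also open, from the compounds shown here alone, is whether the 3-chloro-5-methoxyphenyl group keeps this effect when the chlorine is exchanged for another halogen or a methyl group.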